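Solubility notes: from compound 2 to compound 3

The source may hold more compounds than are shown below. What is called first, only, known or untested is meant among the compounds shown, and "the series" means these compounds.

Measured so far:
compound 1 `COc1cccc(Oc2ccc3c(NCCCNCc4cc(F)ccc4OC)ccnc3c2)c1` gives 14500 nM in a physicochemical assay for solubility, with a stated time of 18 h, at pH 7.4; on this read-out lower numbers stand for lower solubility and higher numbers for higher solubility.
compound 2 `COc1ccc(F)cc1CNCCCNc1ccnc2cc(Cc3cccc(C(F)(F)F)c3)ccc12` gives 4200 nM in this assay.

For the measured compounds named here, compound 2 has the lowest of the two numbers; the only measured step is a 3.5-fold lower number from compound 1 to compound 2 (0.54 log units; beyond the scatter). Compound 3 `COc1ccc(F)cc1CNCCCNc1ccnc2cc(-c3ccc(C(C)(C)C)cc3)ccc12` differs from compound 2 by 4-(tert-butyl)phenyl in place of 3-(trifluoromethyl)benzyl on an aromatic carbon. Going by the values given here, no measured step covers this change; the one step concerns a different group at the same place, so it gives only a rough guide to the scale of variation. For compound 3 the expected step in this assay is a 1.4-fold lower number from compound 2 to compound 3 (0.15 log units; within the scatter), probably within the scatter or slightly downward. Compound 3 is estimated at 3000 nM, with a range from 1000 nM to 10000 nM.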

Compound 3, solubility: 32000 nM
Beside the measured number, compound 3's estimate is 11-fold (1.03 log units) below it, outside the stated range (above it).
By their numbers in this assay, from the lowest: compound 2; then compound 1; then compound 3.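

For the compounds shown here, the read-out at this aromatic carbon runs both ways: in this assay 4-(tert-butyl)phenyl in place of 3-(trifluoromethyl)benzyl brings a 7.6-fold higher number from compound 2 to compound 3 (0.88 log units; beyond the scatter) where the only earlier step went down. The same group in place of 3-methoxyphenoxy brings a 2.2-fold higher number from compound 1 to compound 3 (0.34 log units; beyond the scatter) and leaves compound 3 highest of the three. No data at hand bear on the reason for these steps.

Open, from the compounds shown here alone, is how a plain phenyl, without the tert-butyl group, would read at this aromatic carbon in this assay and whether an amine or a carboxylic acid there would fall within the range of these three compounds.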